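A Benzyl Amide After the Pentyl Amide

The compounds below may be only part of what the source reports. "The series", "measured", "known", "first", "only" and "open" are said of these compounds alone.

In a functional assay on A549 cells (Homo sapiens) for cytotoxicity, read by MTT assay, with a stated time of 48 h (on this read-out higher numbers stand for weaker inhibition and lower numbers for stronger inhibition), compound 1 `CC(C)NC(=O)CC[C@H](NS(=O)(=O)c1ccc([N+](=O)[O-])cc1)C(=O)O` gives > 500000 nM as a limit of the assay. Compound 2 `CC(C)CNC(=O)CC[C@H](NS(=O)(=O)c1ccc([N+](=O)[O-])cc1)C(=O)O` gives > 500000 nM as a limit too. Within the data shown here, compound 3 `CCCCCNC(=O)CC[C@H](NS(=O)(=O)c1ccc([N+](=O)[O-])cc1)C(=O)O` gives 206000 nM as the only real number of the three. The change to compound 4 `O=C(CC[C@H](NS(=O)(=O)c1ccc([N+](=O)[O-])cc1)C(=O)O)NCc1ccccc1` is phenyl in place of butyl on a saturated chain carbon bound to an amide-type nitrogen. Among the measured compounds shown here, two steps bear on it, an at least 2.4-fold lower number from compound 1 to compound 3 (0.38 log units; beyond the scatter) and an at least 2.4-fold lower number from compound 2 to compound 3 (0.38 log units; beyond the scatter), both beyond the scatter, while a step that the two limits leave unreadable from compound 1 to compound 2 adds nothing readable. These steps suggest that the amide substituent matters, so a slightly higher number is expected, though probably nothing beyond the scatter. The expected step is a 1.4-fold higher number from compound 3 to compound 4 (0.13 log units; within the scatter) in this assay overall. For compound 4 the estimate is 280000 nM within an expected range of 120000 nM to 500000 nM in this assay.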

Compound 4, half-maximal inhibitory concentration: 343000 nM
The estimate for compound 4 lay 1.2-fold (0.09 log units) below the measured number, within the range that was stated.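

In this assay, compound 4 shows that a ring-bearing substituent at this amide nitrogen, like the pentyl chain, gives a real number rather than a limit. The change from pentyl to benzyl is a 1.7-fold higher number from compound 3 to compound 4 (0.22 log units; within the scatter), so the two amides cannot be told apart here. Set against the shorter amides, the steps are an at least 1.4-fold lower number from compound 2 to compound 4 (0.16 log units; that floor lies within the scatter) and an at least 1.4-fold lower number from compound 1 to compound 4 (0.16 log units; that floor lies within the scatter), so neither establishes a real separation.

Open, as far as these compounds go, is whether a longer chain such as octyl, or a chlorine on the benzyl ring, would move the number beyond the scatter. Any reading of the shorter amides stays bounded by a limit: the limit of > 500000 nM in this assay, at which 2 of the 4 values shown sit.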